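Pyrrole series: amino-to-chloro swap at the aryl position

The source may hold more compounds than are shown below. What is called first, only, known or untested is meant among the compounds shown, and "the series" means these compounds.

Compound 1 `COc1cc(C(=O)c2cn(-c3ccccc3)cc2-c2ccc(N)cc2)cc(OC)c1OC` is the reference point of the series. Among the measured compounds shown here, in a functional assay on MCF7 cells (Homo sapiens) for cytotoxicity, read by MTT assay, with a stated time of 96 h (a lower number here means a stronger inhibitor, a higher number a weaker inhibitor), compound 1 gives 9 nM, the lower of the two numbers measured so far. For the measured compounds named here, the other measured member, compound 2 `COc1cc(C(=O)c2cn(-c3ccc([N+](=O)[O-])cc3)cc2-c2ccccc2)cc(OC)c1OC`, gives 4000 nM in this assay; its number lies far above that of compound 1, well beyond the scatter, though the two structures differ in more than one place and no single step connects them.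

Compound 3 `COc1cc(C(=O)c2cn(-c3ccccc3)cc2-c2cccc(Cl)c2)cc(OC)c1OC` has not yet been measured. It differs from compound 1 in one place: 3-chlorophenyl in place of 4-aminophenyl on an aromatic carbon.

Going by the values given here, no measured pair shows this kind of change, so the expectation rests on compound 1 alone. The step is expected to weaken inhibition, with an 11-fold higher number from compound 1 to compound 3 (1.05 log units; beyond the scatter) as the estimated size, beyond the scatter. Compound 3 is therefore expected to give about 100 nM in this assay, most plausibly between 20 nM and 500 nM.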

Compound 3, half-maximal inhibitory concentration: 540 nM
Estimate against measurement, compound 3: 5.4-fold (0.73 log units) below; the measured number lies above the stated range.
By their numbers in this assay, from the lowest: compound 1; then compound 3; then compound 2.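

Among the compounds shown here, putting 3-chlorophenyl in place of 4-aminophenyl on this aromatic carbon gives, in this assay, a 60-fold higher number from compound 1 to compound 3 (1.78 log units; beyond the scatter), the first single-place step and a large one, so activity here depends strongly on the aryl group at this position. The swap removes the amino nitrogen, with its hydrogen-bond donor and acceptor, brings in chlorine and also moves the substituent around the phenyl ring, and this single step cannot separate those changes. No measurement in hand explains the size of the step.

Still open, from the compounds shown here alone, is whether the loss follows the identity of the substituent or its place on the phenyl ring. Direct comparisons with compound 1 and compound 3 would come from 3-aminophenyl and 4-chlorophenyl at this carbon, while 4-hydroxyphenyl would test another replacement for the amine.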